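The compounds below may be only part of what the source reports. "The series", "measured", "known", "first", "only" and "open" are said of these compounds alone.

Measured compounds: compound 1 `O=C1/C(=C/c2ccccc2F)CN(S(=O)(=O)c2ccc(O[N+](=O)[O-])cc2)C/C1=C\c1ccccc1F`, 16500 nM; compound 2 `O=C1/C(=C/c2ccccc2F)CN(S(=O)(=O)c2ccc(C(F)(F)F)cc2)C/C1=C\c1ccccc1F`, 4900 nM; compound 3 `O=C1/C(=C/c2cccc(F)c2)CN(S(=O)(=O)c2ccc(O[N+](=O)[O-])cc2)C/C1=C\c1cccc(F)c1`, 8100 nM.

All three were tested in a functional assay on HepG2 cells (Homo sapiens) for cytotoxicity, read by MTT assay, with a stated time of 24 h; on this read-out lower numbers stand for stronger inhibition and higher numbers for weaker inhibition. Compound 1 and compound 2 share a core and differ by one change, (trifluoromethyl in place of nitrooxy on an aromatic carbon), which gave a 3.4-fold lower number from compound 1 to compound 2 (0.53 log units; beyond the scatter). Compound 3 carries a different core; the difference between the two cores is not broken down here. Its number stands within the scatter of compound 2, and the gap between compound 3 and compound 1 is beyond the scatter.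

Compound 4 `O=C1/C(=C/c2cccc(F)c2)CN(S(=O)(=O)c2ccc(C(F)(F)F)cc2)C/C1=C\c1cccc(F)c1` has not been measured. It differs from compound 3 by trifluoromethyl in place of nitrooxy on an aromatic carbon, and its place of change is described in the same words as for compound 1 and compound 2, so it is the same change on a different core. Because the same change gave a 3.4-fold lower number from compound 1 to compound 2 (0.53 log units; beyond the scatter), a step of about a 3.0-fold lower number from compound 3 to compound 4 (0.48 log units; beyond the scatter) is expected from compound 3 to compound 4 in this assay. Compound 4 is accordingly estimated at 2700 nM in this assay, with a likely range from 1200 nM to 6000 nM.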

Compound 4, half-maximal inhibitory concentration: 2400 nM
The estimate for compound 4 lay 1.1-fold (0.05 log units) above the measured number, within the range that was stated.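

In this assay, putting trifluoromethyl in place of nitrooxy on the second core gave a 3.4-fold lower number from compound 3 to compound 4 (0.53 log units; beyond the scatter). Set beside the earlier step on the first core, the change carried over with no difference in size that the scatter would allow one to read: the same change on two cores in this assay, a 3.4-fold lower number (0.53 log units; beyond the scatter) from compound 1 to compound 2 and a 3.4-fold lower number (0.53 log units; beyond the scatter) from compound 3 to compound 4, 1.0-fold (0.00 log units) apart, within the scatter of two such steps. This shows that the step held on these two closely related cores in this one read-out, but it does not show that it would hold on other cores, and one pair per core says nothing about what lies behind its size.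

The compounds shown leave open how other groups at this place on the aromatic ring, such as a nitrile, an amine or a carboxylic acid, would compare with trifluoromethyl and nitrooxy in this assay. They also leave open whether the same step would be seen in any other cell line or at any other exposure time.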